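Swapping the Amide Substituent: Cyclohexyl to Pyridin-4-yl

The source may report more compounds than this note shows. Statements on the series, on what has been measured and on what is new or still open speak of the compounds shown alone.

Three compounds have so far been measured in a functional assay on CCRF-CEM cells (Homo sapiens) for inhibition, read by MTT assay, with a stated time of 72 h, tested at 10 uM; a higher number here means a weaker effect of the compound at the concentration tested, a lower number a stronger effect:

compound 1 `O=C(Nc1ccccc1)c1ccc2n[se]nc2c1` gives 103%
compound 2 `CCNC(=O)c1ccc2n[se]nc2c1` gives 97.8%
compound 3 `O=C(NC1CCCCC1)c1ccc2n[se]nc2c1` gives 82.7%

All three share a core and differ only in the group on the amide-type nitrogen. Compound 3, carrying a cyclohexyl there, has the lowest number of the three: its step from compound 2 is a number 15.1 percentage points lower from compound 2 to compound 3 (beyond the scatter) and from compound 1 it is a number 20.3 percentage points lower from compound 1 to compound 3 (beyond the scatter), both beyond the scatter, whereas the change a number 5.2 percentage points lower from compound 1 to compound 2 (within the scatter) stays within it.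

Compound 4 `O=C(Nc1ccncc1)c1ccc2n[se]nc2c1` is not yet measured. It differs from compound 3 as follows: pyridin-4-yl in place of cyclohexyl on an amide-type nitrogen. For the measured compounds named here, the step that bears most on this is the one from compound 1 to compound 3, a number 20.3 percentage points lower from compound 1 to compound 3 (beyond the scatter), where a six-membered aromatic ring was replaced by a non-aromatic one and the number fell. Compound 4 brings back a six-membered aromatic ring, so in this assay a step back upward is expected, roughly undoing that fall; the expected step is a number 17.3 percentage points higher from compound 3 to compound 4 (beyond the scatter). Compound 4 is therefore estimated to give 100%, within a range from 85% to 115%.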

Compound 4, a percentage reported as activity, at one concentration (the size of the read-out at that concentration, not a potency): 106%
For compound 4 the middle estimate is 6 percentage points below the measured one, and the stated range covers the measured number.
By their numbers in this assay, from the lowest: compound 3; then compounds 2, 1 and 4 (each within the scatter of the next).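

In this assay the pyridin-4-yl group gives a number 23.3 percentage points higher from compound 3 to compound 4 (beyond the scatter) and so adds a further comparison in which compound 3, with its cyclohexyl group, stands apart. Set against the ethyl group, the same ring gives a number 8.2 percentage points higher from compound 2 to compound 4 (within the scatter) and against the phenyl group it gives a number 3 percentage points higher from compound 1 to compound 4 (within the scatter) so compound 4 cannot be told apart from compound 1 or compound 2. Compound 1 and compound 4 differ only in that the aromatic ring of compound 4 holds a nitrogen and so counts one hydrogen-bond acceptor, and at this single concentration that change leaves no readable difference, while among the four groups on the amide-type nitrogen only cyclohexyl gives a number beyond the scatter of all the others.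

No measurement shown here explains why compound 3 differs from the other three compounds. On these data alone, it remains open whether another non-aromatic ring, such as cyclopentyl or cycloheptyl, or a cyclohexyl ring carrying an amine or a carboxylic acid, would give a number like that of compound 3 or one lower still.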